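The compounds below may be only part of what the source reports. "The series", "measured", "known", "first", "only" and "open" are said of these compounds alone.

Compound 1 `CN(C)C(=O)c1cc2cnc(Nc3ccc(NC(=O)C4(C(=O)Nc5cccc(O)c5)CC4)cc3)nc2n1C1CCCC1` gives 58.5% in a functional assay on OVCAR-5 cells (Homo sapiens) for inhibition, read by CCK-8 assay, with a stated time of 72 h, tested at 1 uM; on this read-out lower numbers stand for less inhibition of growth and higher numbers for more inhibition of growth at the one concentration tested. Compound 2 `CN(C)C(=O)c1cc2cnc(Nc3ccc(NC(=O)C4(C(=O)Nc5ccc(Br)cc5)CC4)cc3)nc2n1C1CCCC1` gives 13.7% in this assay.

Going by the values given here, of the two numbers, compound 2 stands lowest, with compound 1 as its only neighbour. Among the compounds with values here, the single measured step, a number 44.8 percentage points lower from compound 1 to compound 2 (beyond the scatter), was large. Compound 3 `CN(C)C(=O)c1cc2cnc(Nc3ccc(NC(=O)C4(C(=O)Nc5cccc(Cl)c5)CC4)cc3)nc2n1C1CCCC1` differs from compound 2 by 3-chlorophenyl in place of 4-bromophenyl on an amide-type nitrogen. Within the data shown here, the measured step exchanged a hydroxyphenyl for a halophenyl on the same amide-type nitrogen; no measured step exchanges one halophenyl for another, so that step offers only indirect guidance. Compound 3 is expected to stay close to compound 2, with an estimated step of a number 11.3 percentage points higher from compound 2 to compound 3 (beyond the scatter) in this assay. The estimate for compound 3 is 25%, in a range from 5% to 50%.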

Compound 3, percent growth inhibition at one concentration: 15.5%
Compound 3: the middle estimate sits 9.5 percentage points above what was measured; the measured number falls inside the stated range.
By their numbers in this assay, from the lowest: compounds 2 and 3 (each within the scatter of the next); then compound 1.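

In this assay, 3-chlorophenyl in place of 4-bromophenyl on the amide-type nitrogen gives a number 1.8 percentage points higher from compound 2 to compound 3 (within the scatter), so this exchange changes both the halogen and its place on the ring without a resolved change in the read-out. With the ring position held, chloro in place of hydroxy on an aromatic carbon gives a number 43 percentage points lower from compound 1 to compound 3 (beyond the scatter), a large step that a single exchange of hydroxy for chloro accounts for in this pair. Nothing available here gives a reason for either step.

From the compounds shown here alone, whether 4-hydroxyphenyl would match compound 1 remains open. So does how an amino or carboxylic acid group on the same ring would read.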